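Cyano to acetamido: what one modest step suggests

The compounds below may be only part of what the source reports. "The series", "measured", "known", "first", "only" and "open" are said of these compounds alone.

Compound 1 `CC(C)(C)C1=NN(c2ccc(Cl)cc2)C(c2ccc(F)cc2)C1` gives 0% in an assay on isolated protein for inhibition of protein kinase C zeta type (Homo sapiens), with a stated time of 4 min, tested at 62.5 uM; a higher number here means more inhibition at the concentration tested (going by the name of the read-out), a lower number less inhibition. Compound 2 `CC(C)(C)C1=NN(c2ccc(Cl)cc2)C(c2ccc(C#N)cc2)C1` gives 20.7% in this assay, the higher of the two values, reached through a step of a number 20.7 percentage points higher from compound 1 to compound 2 (beyond the scatter). Compound 3 `CC(=O)Nc1ccc(C2CC(C(C)(C)C)=NN2c2ccc(Cl)cc2)cc1` differs from compound 2 by acetamido in place of cyano on an aromatic carbon. Among the compounds with values here, only that one modest step bears on this change, and it concerns a different group, so little can be drawn from it. The expected step is a number 1.3 percentage points higher from compound 2 to compound 3 (within the scatter), small at best. Compound 3 is therefore expected to give about 22% in this assay, within a range from 0% to 45%.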

Compound 3, a percentage reported as inhibition, at one concentration (the size of the read-out at that concentration, not a potency): 45.1%
Compound 3: middle estimate off by 23.1 percentage points, on the low side; the measured number lies above the stated range.
By their numbers in this assay, from the lowest: compound 1; then compound 2; then compound 3.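

In this assay, the position para to a large group responds far more than the first step showed: acetamido in place of cyano gives a number 24.4 percentage points higher from compound 2 to compound 3 (beyond the scatter), and acetamido in place of fluoro gives a number 45.1 percentage points higher from compound 1 to compound 3 (beyond the scatter). Among these compounds, the numbers rise from fluoro through cyano to acetamido, and unlike cyano, acetamido has a hydrogen-bond donor and more heavy atoms. No measurement here explains the rise.

Going by these compounds, it remains open whether the donor, the larger size or neither matters. An amine or a longer amide chain at this position could help separate these possibilities.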